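The source may report more compounds than this note shows. Statements on the series, on what has been measured and on what is new or still open speak of the compounds shown alone.

Of the compounds shown here, three built on one shared core have been tested in a functional assay on U-87MG ATCC cells for cytotoxicity against U-87 MG (Homo sapiens), read by MTT assay, with a stated time of 72 h; on this read-out higher numbers stand for weaker inhibition and lower numbers for stronger inhibition. Compound 1 `O=C(Nc1nc2ccc(Cl)cc2s1)c1cn(-c2ccccc2)nc1-c1ccc(F)cc1` gives 6770 nM in this assay. Compound 3 `O=C(Nc1nc2ccc(Cl)cc2s1)c1cn(-c2ccccc2)nc1-c1ccc(Cl)cc1` gives 5870 nM in this assay. Compound 3 differs from compound 1 only in that (chloro in place of fluoro on an aromatic carbon), a change that made a 1.2-fold lower number from compound 1 to compound 3 (0.06 log units; within the scatter). Compound 2 `COc1ccc2nc(NC(=O)c3cn(-c4ccccc4)nc3-c3ccc(F)cc3)sc2c1` differs from compound 1 in that (methoxy in place of chloro on an aromatic carbon). For compound 2, this assay reports only a limit, > 50000 nM. That change therefore made an at least 7.3-fold higher number from compound 1 to compound 2 (0.86 log units; beyond the scatter), with the number running into (the limit of > 50000 nM in this assay, at which 1 of the 3 values shown sits).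

Compound 4 `COc1ccc2nc(NC(=O)c3cn(-c4ccccc4)nc3-c3ccc(Cl)cc3)sc2c1` has not yet been measured. Among the measured compounds shown here, it differs from compound 3 in that (methoxy in place of chloro on an aromatic carbon), the same change, at the same place, as the one from compound 1 to compound 2. Since on compound 1 that change gave an at least 7.3-fold higher number from compound 1 to compound 2 (0.86 log units; beyond the scatter), compound 4 is expected to show a step of about an 8.5-fold higher number from compound 3 to compound 4 (0.93 log units; beyond the scatter). Compound 4 is therefore estimated at 50000 nM, with a range from 20000 nM to 150000 nM, and it is expected that this assay may again report only a limit rather than a number.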

Compound 4, half-maximal inhibitory concentration: 21200 nM
Beside the measured number, compound 4's estimate is 2.4-fold (0.37 log units) above it; measured number inside the range.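

In this assay, putting methoxy in place of chloro raises the number on the second core as well, giving a 3.6-fold higher number from compound 3 to compound 4 (0.56 log units; beyond the scatter), so the direction of this change carries over: the same change on two cores in this assay, an at least 7.3-fold higher number (0.86 log units; beyond the scatter) from compound 1 to compound 2 and a 3.6-fold higher number (0.56 log units; beyond the scatter) from compound 3 to compound 4; the limit leaves it open whether they differ

As far as these compounds go, compound 2 gives > 50000 nM, which is a limit and not a number, so it stays unknown whether the change has the same size on both cores. With chloro in place of fluoro, the step is an at least 2.3-fold lower number from compound 2 to compound 4 (0.37 log units; beyond the scatter); it rests on the same limit, so it too cannot be compared in size with the earlier step for that change: the same change on two cores in this assay, a 1.2-fold lower number (0.06 log units; within the scatter) from compound 1 to compound 3 and an at least 2.3-fold lower number (0.37 log units; beyond the scatter) from compound 2 to compound 4; the limit leaves it open whether they differ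

Among the compounds shown here, the methoxy change has been seen on only two cores, which differ from each other by a single halogen, so cores that differ more remain untested here. Also open, from the compounds shown here alone, is whether another group at the same place, such as an amine, a hydroxyl or a methyl, would read closer to chloro or to methoxy in this assay.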